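This account rests on a few compounds, and the source may have more. Where it says the series, first, only, none or still open, it means among the compounds named here.

Measured so far:
compound 1, `COc1ncc(-c2ccc3nc(NC(=O)NCC(=O)N4CCCC4)nn3c2)cc1NS(=O)(=O)c1ccc(F)cc1`, gives 1000 nM in a functional assay on U-87MG ATCC cells for cytotoxicity against U-87 MG (Homo sapiens), read by MTT assay, with a stated time of 72 h; on this read-out lower numbers stand for stronger inhibition and higher numbers for weaker inhibition;
compound 2, `CCN(CC)CCNC(=O)Nc1nc2ccc(-c3cnc(OC)c(NS(=O)(=O)c4ccc(C)cc4)c3)cn2n1`, gives 670 nM in this assay.

Compound 1 has the higher of these two numbers, yet the gap to compound 2 lies within the usual scatter of repeated measurements, so on this read-out the two compounds cannot be told apart. Compound 3, `COc1ncc(-c2ccc3nc(NC(=O)NCC(=O)N4CCOCC4)nn3c2)cc1NS(=O)(=O)c1ccc(F)cc1`, has not yet been measured. It differs from compound 1 in a single place: morpholin-4-yl in place of pyrrolidin-1-yl on a carbonyl carbon. Within the data shown here, no pair of measured compounds shows this exchange, so there is no known step to lean on; what can be said rests only on compound 1 and its value of 1000 nM in this assay. With a change confined to the ring at the end of the side chain and nothing in the two measured values pointing in either direction, the expectation for compound 3 is a step of no change at the digits printed from compound 1 to compound 3 (within the scatter), that is, none beyond the scatter. Compound 3 is therefore estimated at 1000 nM in this assay, with a range from 400 nM to 2500 nM.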

Compound 3, half-maximal inhibitory concentration: 3260 nM
For compound 3 the middle estimate is 3.3-fold (0.51 log units) below the measured one; measured number outside the range, above it.
By their numbers in this assay, from the lowest: compounds 2 and 1 (each within the scatter of the next); then compound 3.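

The end of the side chain is not a silent place: in this assay, morpholin-4-yl in place of pyrrolidin-1-yl on a carbonyl carbon gives a 3.3-fold higher number from compound 1 to compound 3 (0.51 log units; beyond the scatter), so inhibition is weaker after this exchange. Compound 1 and compound 2 could not show this, as they differ in more than one place and their values lie within the scatter of each other. Here a single exchange is seen to move the number, with a five-membered ring giving way to a six-membered ring that carries an oxygen and one hydrogen-bond acceptor, but nothing available explains why the number rises.

The compounds shown leave open whether the step goes with the larger ring or with the oxygen, and piperidin-1-yl on the same carbonyl carbon, a six-membered ring without that oxygen, would separate the two. Also open, on these data alone, is whether a ring is needed here at all, a question that an open-chain group such as dimethylamino in the same place would address.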